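This account rests on a few compounds, and the source may have more. Where it says the series, first, only, none or still open, it means among the compounds named here.

Measured compounds:
- compound 1 `CNC(=O)c1cc(Oc2ccc(/C=C/C(=O)c3ccc([N+](=O)[O-])cc3)cc2)ccn1` gives 54300 nM
- compound 2 `CNC(=O)c1cc(Oc2ccc(C(=O)/C=C/c3ccc(Cl)cc3Cl)cc2)ccn1` gives 3990 nM

The two measured compounds share a core and differ in how the enone chain is built and in what sits on its far ring. In a functional assay on MCF7 cells (Homo sapiens) for cytotoxicity, read by MTT assay, with a stated time of 72 h (on this read-out lower numbers stand for stronger inhibition and higher numbers for weaker inhibition), compound 1 gives 54300 nM, while in this assay compound 2 gives 3990 nM. Compound 2 therefore stands with the lowest number of the two; the nearest, compound 1, lies well beyond the scatter above it.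

Compound 3 `CNC(=O)c1cc(Oc2ccc(C(=O)/C=C/c3ccc(Cl)c(Cl)c3)cc2)ccn1` has not been measured. It carries the same atoms as compound 2, joined differently: 3,4-dichlorophenyl in place of 2,4-dichlorophenyl on a double-bonded chain carbon bound to a double-bonded chain carbon. For the measured compounds named here, no step between measured compounds shows what moving the two chlorines on that ring does, so the account rests on compound 2 alone. Since the two rings carry the same atoms and the chain and core are untouched, a step of no more than the usual scatter is expected from compound 2 to compound 3, with no firm direction, as a 1.0-fold higher number from compound 2 to compound 3 (0.00 log units; within the scatter) expresses. On that basis compound 3 is expected to give about 4000 nM in this assay, within a range from 1500 nM to 12000 nM.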

Compound 3, half-maximal inhibitory concentration: 13200 nM
Compound 3: the middle estimate sits 3.3-fold (0.52 log units) below what was measured, and the stated range ends below it.
By their numbers in this assay, from the lowest: compound 2; then compound 3; then compound 1.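

Moving the two chlorines is not a neutral change: in this assay, 3,4-dichlorophenyl in place of 2,4-dichlorophenyl on a double-bonded chain carbon bound to a double-bonded chain carbon gives a 3.3-fold higher number from compound 2 to compound 3 (0.52 log units; beyond the scatter). For the compounds shown here, this is the first comparison that changes one place only, and it shows that the read-out at this position depends on where the chlorines sit on the ring, even though the atoms, the chain and the shared core stay the same, and the count of hydrogen-bond donors and acceptors in the group stays at zero. Nothing measured here bears on why the number moves with this shift of the chlorines.

The compounds shown leave open whether a methoxy group, a single fluorine or an amine on that ring would bring the number below that of compound 2 or raise it further. Compound 1 differs from compound 2 and compound 3 in both the build of the enone chain and the group on its ring, so it cannot show how either change acts alone.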